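The source may report more compounds than this note shows. Statements on the series, on what has been measured and on what is new or still open speak of the compounds shown alone.

Measured so far in an assay on HEK293 cells for displacement of a labelled ligand from corticotropin-releasing factor receptor 1 (Homo sapiens); a lower number here means a stronger inhibitor, a higher number a weaker inhibitor:

- compound 1 `CCCCN(CCCC)c1cc(C)nc2c(-c3ccc(Cl)cc3Cl)nn(C)c12`: 0.62 nM
- compound 2 `CCCCCN(CCCC)c1cc(C)nc2c(-c3ccc(Cl)cc3Cl)nn(C)c12`: 0.9 nM
- compound 3 `CCCCN(CCCOC)c1cc(C)nc2c(-c3ccc(Cl)cc3Cl)nn(C)c12`: 18 nM

Compound 3 holds the highest number of the three. Its nearest neighbour is compound 2, and the step of a 20-fold higher number from compound 2 to compound 3 (1.30 log units; beyond the scatter) is beyond the scatter; the step of a 29-fold higher number from compound 1 to compound 3 (1.46 log units; beyond the scatter) is larger still. The step of a 1.5-fold higher number from compound 1 to compound 2 (0.16 log units; within the scatter) lies within the scatter, so chain length alone did not move this assay, whereas bringing the methoxy in did.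

Compound 4 `CCCCN(Cc1ccncc1)c1cc(C)nc2c(-c3ccc(Cl)cc3Cl)nn(C)c12` differs from compound 3 in one place: pyridin-4-yl in place of 2-methoxyethyl on a saturated chain carbon bound to a nitrogen on an aromatic ring. Within the data shown here, no measured step covers a ring on this chain, so the only guidance is that the one acceptor-bearing chain in the set, in compound 3, reads far weaker than the plain chains of compound 1 and compound 2. The pyridin-4-yl group keeps one acceptor but trades the 2-methoxyethyl for a six-membered aromatic ring, so the direction is open; the expectation is for a modest change at most, on either side of compound 3, with wide uncertainty.

For compound 4 the estimate is 8 nM (range 1.5 nM to 45 nM), expected to correspond to a step of a 2.3-fold lower number from compound 3 to compound 4 (0.35 log units; beyond the scatter).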

Compound 4, inhibition constant: 68 nM
For compound 4 the middle estimate is 8.5-fold (0.93 log units) below the measured one; the whole stated range lies below it.
By their numbers in this assay, from the lowest: compounds 1 and 2 (each within the scatter of the next); then compound 3; then compound 4.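

In this assay the change to pyridin-4-yl does not win back the ground lost with the methoxy but moves further the same way (a 3.8-fold higher number from compound 3 to compound 4 (0.58 log units; beyond the scatter)), and the distance from the plain chains grows (a 76-fold higher number from compound 2 to compound 4 (1.88 log units; beyond the scatter); a 110-fold higher number from compound 1 to compound 4 (2.04 log units; beyond the scatter)). On a saturated chain carbon bound to a nitrogen on an aromatic ring, this series therefore tolerates the six-membered aromatic ring less well than either the 2-methoxyethyl or the plain chains, and since 2-methoxyethyl and pyridin-4-yl each count one hydrogen-bond acceptor and no donor, that count alone does not set the number at this position. Nothing available here bears on what lies behind these steps.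

A benzyl chain, with a plain phenyl ring in place of pyridin-4-yl, would be needed to tell the effect of the ring from that of its ring nitrogen, and pyridin-2-yl or pyridin-3-yl would show whether the place of that nitrogen matters. Also open, as far as these compounds go, is how a chain ending in a hydroxyl or an amine would read against the 2-methoxyethyl of compound 3.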